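Hydroxypropyl for oxetanyl on the amide nitrogen

The source may report more compounds than this note shows. Statements on the series, on what has been measured and on what is new or still open speak of the compounds shown alone.

Compound 2 `Cc1ccc(OCC(=O)N(Cc2cccs2)C2COC2)cc1` was tested in an assay on HEK293 cells for agonist activity at transient receptor potential cation channel subfamily M member 8 (Homo sapiens), read by fluorescence and calcium flux, with a stated time of 15 min (a higher number here means that more compound is needed for the effect, a lower number that less compound is needed), and gives 23000 nM. That is the highest of the three numbers in hand. Compound 1 `CCN(Cc1ccoc1)C(=O)COc1ccc(C)cc1` in this assay gives 136 nM, and compound 3 `O=C(COc1ccc2c(c1)CCC2)N(Cc1cccs1)c1ccn[nH]1` in this assay gives 0.001 nM; both stand far below compound 2, and these gaps are beyond the usual scatter. Going by the values given here, no single-point step between measured compounds is available, so the comparisons rest on the values alone.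

Compound 4 `Cc1ccc(OCC(=O)N(CCCO)Cc2cccs2)cc1` is not yet measured. It differs from compound 2 in one place: 3-hydroxypropyl in place of oxetan-3-yl on an amide-type nitrogen. Both groups carry the same count of heavy atoms, but the four-membered ring is exchanged for an open chain that adds a hydrogen-bond donor. Among the compounds with values here, with no measured step of this kind to lean on, the outcome is uncertain. The step is expected to be a modest lowering of the number, a 2.9-fold lower number from compound 2 to compound 4 (0.46 log units; beyond the scatter), in the direction of compound 1 but not reaching it. For compound 4 in this assay the estimate is 8000 nM, with a range from 1500 nM to 40000 nM.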

Compound 4, half-maximal effective concentration: 3000 nM
Estimate against measurement, compound 4: 2.7-fold (0.43 log units) above; the measured number falls inside the stated range.
By their numbers in this assay, from the lowest: compound 3; then compound 1; then compound 4; then compound 2.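

Going by these compounds alone, this is the first readable step at this place. On the amide-type nitrogen, the open 3-hydroxypropyl chain in place of the four-membered oxetan-3-yl ring gives in this assay a 7.7-fold lower number from compound 2 to compound 4 (0.88 log units; beyond the scatter) and so moves the number down, not up, with the heavy-atom count unchanged. The change removes the ring and adds a hydrogen-bond donor at once, so the step cannot assign the shift to either, and no measured evidence bears on why the number moved.

The compounds shown leave open whether the hydroxyl or the open chain carries the step, which a 3-methoxypropyl or plain propyl group on this nitrogen would help separate. They also leave open how a 3-aminopropyl group or a longer 4-hydroxybutyl chain would read here.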